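Removing the aminoethyl chain from a trifluoromethyl indazole

The source may hold more compounds than are shown below. What is called first, only, known or untested is meant among the compounds shown, and "the series" means these compounds.

Of the compounds shown here, three that share the same core have so far been measured in an assay for inhibition of Tryptophan 2,3-dioxygenase (Homo sapiens), with stated times of 10 min and 60 min, tested at 10 uM; on this read-out higher numbers stand for a stronger effect at the one concentration tested and lower numbers for a weaker effect. Compound 1 `Nc1cccc(CNc2cc(C(F)(F)F)cc3[nH]ncc23)c1` gives 68% in this assay. Compound 3 `O=[N+]([O-])c1ccc(CNc2cc(C(F)(F)F)cc3[nH]ncc23)cc1`, which carries a nitro group on its benzyl ring, gives 47%. Compound 2 `NCCn1ncc2c(NCc3ccccc3[N+](=O)[O-])cc(C(F)(F)F)cc21` stands lowest of the three with 25%: its number lies under that of compound 3 and further still under that of compound 1, and both gaps are beyond the usual scatter.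

Compound 4 `O=[N+]([O-])c1ccccc1CNc1cc(C(F)(F)F)cc2[nH]ncc12` has not yet been measured. It differs from compound 2 in one place: hydrogen in place of 2-aminoethyl on an aromatic nitrogen. Both compound 1 and compound 3 carry hydrogen on that ring nitrogen and both score higher than compound 2, so a rise is expected, although neither of them is a single-change neighbour of compound 2 and the nitro group of compound 4 sits differently from that of compound 3. The step from compound 2 to compound 4 is therefore estimated as a number 20 percentage points higher from compound 2 to compound 4 (beyond the scatter), a gain beyond the scatter. For compound 4 the inhibition is expected to be 45%, with a range from 22% to 68%.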

Compound 4, a percentage reported as inhibition, at one concentration (the size of the read-out at that concentration, not a potency): 89%
Beside the measured number, compound 4's estimate is 44 percentage points below it, and the stated range ends below it.
By their numbers in this assay, from the lowest: compound 2; then compound 3; then compound 1; then compound 4.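

Going by these compounds alone, the pair of compound 2 and compound 4 is the first to isolate this ring nitrogen: in this assay, putting hydrogen in place of 2-aminoethyl on an aromatic nitrogen gives a number 64 percentage points higher from compound 2 to compound 4 (beyond the scatter), a large step with the rest of the structure unchanged. Until now, the low number of compound 2 could not be tied to any single feature, as compound 1 and compound 3 each differ from it in more than one place. This pair ties the gap to the 2-aminoethyl chain, although no data shown here explain why the number moves so far at this nitrogen.

From the compounds shown here alone, it remains open whether the drop belongs to the terminal amine or to any group on this nitrogen; a methyl group, a 2-hydroxyethyl chain or a longer aminoalkyl chain in that place would separate these readings. It is also open whether the step would keep its size with the nitro group elsewhere on the benzyl ring or with an amine in its place, as the compounds shown offer only this one pair.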